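Swapping a Sulfur Ring for an Aminomethylphenyl Group

A few compounds are considered here, and "the series" means these few. Any claim that something is new, unique, unknown or untested is made for them only; others in the source may bear on it.

Measured so far:
compound 1, `c1ccc2c(c1)CN[C@@H](CN(CCCCNCC1CCSCC1)[C@H]1CCCc3cccnc31)C2`: > 30000 nM
compound 2, `O=S1(=O)CCC(CNCCCCN(C[C@H]2Cc3ccccc3CN2)[C@H]2CCCc3cccnc32)CC1`: > 30000 nM

In a functional assay on cells for agonist activity at C-X-C chemokine receptor type 4 (Homo sapiens), read by fluorescence and calcium flux, with a stated time of 90 s (on this read-out lower numbers stand for an effect already at smaller amounts and higher numbers for an effect only at larger amounts of compound), compound 1 reaches only the limit of the assay, > 30000 nM, so no number is known for it. Compound 2 likewise gives only a limit, > 30000 nM. The change from compound 1 to compound 2 is therefore a step that the two limits leave unreadable from compound 1 to compound 2, because of the limit of > 30000 nM in this assay, at which 2 of the 2 values shown sit.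

Compound 3, `NCc1cccc(CN(C[C@H]2Cc3ccccc3CN2)[C@H]2CCCc3cccnc32)c1`, has not been measured. It differs from compound 1 in this way: a group of 8 heavy atoms (7 carbon, 1 nitrogen; one six-membered aromatic ring of carbon only) in place of a group of 11 heavy atoms (9 carbon, 1 nitrogen, 1 sulfur; one six-membered non-aromatic ring with 1 hetero atom), on a saturated chain carbon bound to an amine nitrogen. Within the data shown here, no measured step bears on this change; the only step available, from compound 1 to compound 2, concerns a different group and is itself unreadable. Nothing among the numbers therefore shows in which direction this change moves activity, or whether it moves it at all beyond the usual scatter.

Starting from a limit, the most that can be said is that compound 3 is expected to sit near that same limit, an estimated step of a number no higher from compound 1 to compound 3 (the limit leaves the size open). Compound 3 is thus estimated at 30000 nM, in the range 5000 nM to 100000 nM, with a real chance that the assay again reports only a limit.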

Compound 3, half-maximal effective concentration: > 30000 nM
Compound 3: no number, only a limit; the forecaster's own chance of this, stated with the estimate: 65%; the middle value sits exactly at the limit.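

In this assay, compound 3 gives only a limit (> 30000 nM). The change from compound 1 to compound 3 therefore cannot be read, because all the results stop at the same point: (the limit of > 30000 nM in this assay, at which 3 of the 3 values shown sit). Still open is whether any of these compounds has an effect in this assay, and how compound 1, compound 2 and compound 3 truly compare.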